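Side chain change from compound 3 to compound 4

The source may hold more compounds than are shown below. What is called first, only, known or untested is meant among the compounds shown, and "the series" means these compounds.

Measured in a functional assay on A549 cells (Homo sapiens) for antiproliferative activity, read by MTT assay, with a stated time of 48 h; a lower number here means a stronger inhibitor, a higher number a weaker inhibitor:
- compound 1 `Cn1cc(C2=C(c3nn(CCCn4cncn4)c4ncccc34)C(=O)NC2=O)c2ccccc21`: > 100000 nM (a limit)
- compound 2 `Cn1cc(C2=C(c3nn(CCn4ccnc4)c4ncccc34)C(=O)N(c3ccccc3)C2=O)c2ccccc21`: 43100 nM
- compound 3 `Cn1cc(C2=C(c3nn(CCCN4CCCCC4)c4ncccc34)C(=O)NC2=O)c2ccccc21`: > 100000 nM (a limit)

Compound 3 has only a limit, > 100000 nM. This is the limit of > 100000 nM in this assay, at which 2 of the 3 values shown sit.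

Compound 4 `Cn1cc(C2=C(c3nn(CCn4ccnc4)c4ncccc34)C(=O)NC2=O)c2ccccc21` is not yet measured. Its difference from compound 3 is 1H-imidazol-1-yl in place of (piperidin-1-yl)methyl on a saturated chain carbon, two bonds along the chain from an aromatic nitrogen. Cut one bond further out, the change reads 3-(piperidin-1-yl)propyl to 2-(1H-imidazol-1-yl)ethyl.

For the measured compounds named here, the one measured step on this chain is a step that the two limits leave unreadable from compound 1 to compound 3, so it gives no size to carry over. Going by the values given here, compound 2 gives 43100 nM, the only number in the set. It carries the same 2-(1H-imidazol-1-yl)ethyl as compound 4 but differs from it elsewhere on the core.

Compound 4 is therefore expected to sit near the limit of compound 3 in this assay, with no firm direction of change. The expected step is a number no higher from compound 3 to compound 4 (the limit leaves the size open). The estimate for compound 4 is 100000 nM. The expected range for compound 4 runs from 40000 nM to 250000 nM.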

Compound 4, half-maximal inhibitory concentration: > 100000 nM
Compound 4: no number, only a limit (the forecaster's own chance of this, stated with the estimate: 65%); the middle value lies on the limit itself.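

In this assay compound 4 gives > 100000 nM, which is a limit and not a number. For the compounds shown here, with the 2-(1H-imidazol-1-yl)ethyl chain held constant, the one remaining difference is on the amide-type nitrogen in a ring, and hydrogen in place of phenyl there gives an at least 2.3-fold higher number from compound 2 to compound 4 (0.36 log units; beyond the scatter), so the only measurable value in the set goes with the phenyl group. The steps among the compounds carrying the amide hydrogen cannot be read, so this read-out does not separate their side chains: the limit of > 100000 nM in this assay, at which 3 of the 4 values shown sit.

Going by these compounds, whether a methyl or benzyl group on that nitrogen would also give a measurable value remains open. Also open, on these data alone, is whether phenyl there would bring compounds with the 3-(piperidin-1-yl)propyl chain or a morpholine-bearing chain off the limit.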